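The compounds below may be only part of what the source reports. "The series", "measured", "known", "first", "only" and "open" are said of these compounds alone.

Working notes on the series. In a functional assay on MGC-803 cells (Homo sapiens) for antiproliferative activity, read by CCK-8 assay, with a stated time of 72 h, tested at 8 uM (on this read-out higher numbers stand for a stronger effect at the one concentration tested and lower numbers for a weaker effect), compound 1 `Nc1ccccc1NC(=O)c1ccc(CSC(=S)N2CCN(c3ccc(Cl)cc3)CC2)cc1` gives 17.2%, compound 2 `Nc1ccccc1NC(=O)c1ccc(CSC(=S)N2CCc3cc(Cl)ccc32)cc1` gives 82.2%, and compound 3 `CC1CCN(C(=S)SCc2ccc(C(=O)Nc3ccccc3N)cc2)CC1` gives 81.9%. Compound 1 thus stands lowest of the three, with both compound 3 and compound 2 beyond the scatter above it, compound 3 being the nearer of the two. Within the data shown here, the one measured step that changes a single place is a number 0.3 percentage points lower from compound 2 to compound 3 (within the scatter); it alters the group on the thiocarbonyl carbon and leaves the read-out essentially where it was.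

Compound 4 `Nc1ccccc1NC(=O)c1ccc(CSC(=S)N2CCN(Cc3cccnc3)CC2)cc1` keeps the shared core of compound 1 and differs from it only by (pyridin-3-yl)methyl in place of 4-chlorophenyl on an amine nitrogen in a ring. Among the measured compounds shown here, no measured step touches this place, so the step from compound 2 to compound 3 bears on it only indirectly: it shows that a swap elsewhere need not move the read-out at all. For the measured compounds named here, what the values do show is that compound 1, the only member carrying 4-chlorophenyl on that ring nitrogen, sits far below compound 2 and compound 3. With that group gone, compound 4 is expected to rise by a number 27.8 percentage points higher from compound 1 to compound 4 (beyond the scatter), though with wide uncertainty. The estimate for compound 4 in this assay is therefore 45%, within 15% to 80%.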

Compound 4, a percentage reported as inhibition, at one concentration (the size of the read-out at that concentration, not a potency): 64.6%
Compound 4: middle estimate off by 19.6 percentage points, on the low side; the measured number falls inside the stated range.
By their numbers in this assay, from the lowest: compound 1; then compound 4; then compounds 3 and 2 (each within the scatter of the next).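

The ring nitrogen of the shared core proves to be a place that strongly moves the read-out in this assay: there is a number 47.4 percentage points higher from compound 1 to compound 4 (beyond the scatter), with (pyridin-3-yl)methyl in place of 4-chlorophenyl. The two groups have the same number of heavy atoms and each carries one six-membered aromatic ring, so a large step here does not depend on a change in the count of heavy atoms, unlike what the earlier single-place step on the thiocarbonyl carbon could show, since that step stayed within the scatter. No measurement among those shown speaks to what lies behind this step.

The swap changes several things at once: the chlorine leaves, a ring nitrogen with one hydrogen-bond acceptor enters, and a methyl link now stands between the aromatic ring and the ring nitrogen, and the compounds shown do not separate these changes. Benzyl or 4-chlorobenzyl on the same nitrogen, or pyridin-3-yl attached directly, would tell whether the link, the chlorine or the pyridine nitrogen carries the step.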